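The compounds below may be only part of what the source reports. "The series", "measured", "known", "first", "only" and "open" are said of these compounds alone.

Measured in an ADME assay on Vero cells (Chlorocebus sabaeus) for cytotoxicity; on this read-out higher numbers stand for lower toxicity in this test and lower numbers for higher toxicity in this test:
- Compound 1 `CC(=O)c1c(Nc2ccc(F)cc2F)[nH]c2c(F)cc(F)cc2c1=O`: > 25000 nM, a limit
- Compound 2 `CCCCNc1[nH]c2c(F)cc(F)cc2c(=O)c1C(C)=O`: > 25000 nM, a limit
- Compound 3 `COc1cccc(Nc2[nH]c3c(F)cc(F)cc3c(=O)c2C(C)=O)c1`: > 25000 nM, a limit

Compound 3 stands at > 25000 nM, which is a limit and not a number. Within the data shown here, it shares that position with the other two compounds, so the series so far offers only (the limit of > 25000 nM in this assay, at which 3 of the 3 values shown sit).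

The next compound, compound 4 `COc1ccc(Nc2[nH]c3c(F)cc(F)cc3c(=O)c2C(C)=O)cc1`, has the same atoms as compound 3, joined differently: 4-methoxyphenyl in place of 3-methoxyphenyl on a nitrogen on an aromatic ring. A 4-methoxyphenyl sits in place of 3-methoxyphenyl on a nitrogen on an aromatic ring.

Among the measured compounds shown here, two measured steps bear on this change, as both alter the same substituent: a step that the two limits leave unreadable from compound 1 to compound 3 and a step that the two limits leave unreadable from compound 2 to compound 3. Neither has a readable size, and neither shows any departure from the limit. The same is true of a step that the two limits leave unreadable from compound 1 to compound 2.

No step beyond the scatter is therefore expected in this assay, and no direction can be favoured. The expected change is a step that the limit leaves unreadable from compound 3 to compound 4. Compound 4 will most likely be reported only as a limit again. As a value, compound 4 is estimated at 30000 nM, with an expected range of 15000 nM to 60000 nM.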

Compound 4, half-maximal cytotoxic concentration: > 25000 nM
Compound 4 was reported as a limit; the forecaster's own chance of this, stated with the estimate: 85%; the middle value is on the limit's open side.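

In this assay compound 4 gives > 25000 nM, a limit, so none of its steps from compound 1, compound 2 or compound 3 can be read. The compounds shown leave open whether the group on the nitrogen changes this read-out at all: the limit of > 25000 nM in this assay, at which 4 of the 4 values shown sit.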